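Swapping an isopentyl chain for a methoxyphenyl ring

The source may report more compounds than this note shows. Statements on the series, on what has been measured and on what is new or still open speak of the compounds shown alone.

Of the compounds shown here, three built on one shared core have been measured in an ADME assay on HepG2 cells (Homo sapiens) for cytotoxicity, read by luminescence, CellTiter-Glo and ATP content, with a stated time of 72 h; on this read-out lower numbers stand for an effect already at smaller amounts and higher numbers for an effect only at larger amounts of compound. Compound 1 `FC(F)(F)c1ccc(-c2ccc3c(NCCCNCc4ccco4)ccnc3c2)cc1` carries a 4-(trifluoromethyl)phenyl group and gives 3470 nM. Compound 2 `CC(C)Cc1ccc2c(NCCCNCc3ccco3)ccnc2c1` carries an isobutyl group in its place and gives 16000 nM. Compound 3 `CC(C)CCc1ccc2c(NCCCNCc3ccco3)ccnc2c1` carries an isopentyl group and gives 11200 nM, the second highest of the three numbers, though it sits within the scatter of compound 2. Replacing the aromatic group by a chain gave a 4.6-fold higher number from compound 1 to compound 2 (0.66 log units; beyond the scatter) and a 3.2-fold higher number from compound 1 to compound 3 (0.51 log units; beyond the scatter), whereas lengthening the chain gave a 1.4-fold lower number from compound 2 to compound 3 (0.15 log units; within the scatter).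

Compound 4 `COc1ccc(-c2ccc3c(NCCCNCc4ccco4)ccnc3c2)cc1` has not yet been measured. It differs from compound 3 by 4-methoxyphenyl in place of isopentyl on an aromatic carbon. This reverses the kind of change seen when an aromatic group gave way to a chain, and the step that bears on it most directly, a 3.2-fold higher number from compound 1 to compound 3 (0.51 log units; beyond the scatter), was a modest rise, so a modest fall is expected in this assay. Compound 4 is therefore estimated at 4500 nM, with a range from 1500 nM to 13000 nM, an expected 2.5-fold lower number from compound 3 to compound 4 (0.40 log units; beyond the scatter).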

Compound 4, half-maximal effective concentration: 6000 nM
Estimate against measurement, compound 4: 1.3-fold (0.12 log units) below; low and high end bracket the measured number.
By their numbers in this assay, from the lowest: compounds 1, 4, 3 and 2 (each within the scatter of the next, the first and the last beyond it).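

At this position on the shared core, a 4-methoxyphenyl group in place of a chain gives a 1.9-fold lower number from compound 3 to compound 4 (0.27 log units; within the scatter) against isopentyl and a 2.7-fold lower number from compound 2 to compound 4 (0.43 log units; beyond the scatter) against isobutyl, so the ring stands clear of only one of the two chains. Methoxy in place of trifluoromethyl on the ring gives a 1.7-fold higher number from compound 1 to compound 4 (0.24 log units; within the scatter), so these two ring-bearing compounds cannot be told apart here, although only compound 1 lies beyond the scatter of both chain compounds. Nothing measured here explains these numbers.

A plain phenyl ring, or a phenyl ring carrying an amine or a carboxylic acid, could show whether the ring itself or its substituent sets the number. A longer chain at the same place could show whether chain length matters at all.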